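The source may hold more compounds than are shown below. What is called first, only, known or untested is meant among the compounds shown, and "the series" means these compounds.

Compound 1 `COc1ccc(/C=C2\CCC/C(=C\c3cccc(Cl)c3)C2=O)cc1OC`: 11900 nM
Compound 2 `COc1ccc(/C=C2\CCC/C(=C\c3cccc(O)c3)C2=O)cc1OC`: 6800 nM

For the measured compounds named here, in an ADME assay on NHDF cells (Homo sapiens) for cytotoxicity, read by MTT assay, with a stated time of 72 h (a lower number here means a stronger inhibitor, a higher number a weaker inhibitor), compound 2 gives 6800 nM and stands level with the only other measured compound, since the two lie within the scatter of each other. Compound 3 `COc1ccc(/C=C2\CCC/C(=C\c3cccc(Cl)c3Cl)C2=O)cc1OC` has 2,3-dichlorophenyl in place of 3-hydroxyphenyl on a double-bonded chain carbon bound to a double-bonded ring carbon. Going by the values given here, one measured step bears on this change, a swap of chloro to hydroxy: a 1.8-fold lower number from compound 1 to compound 2 (0.24 log units; within the scatter). Among the compounds with values here, no measured compound has two chlorines on this ring, so no step beyond the scatter is expected. The expected change is a 1.5-fold higher number from compound 2 to compound 3 (0.17 log units; within the scatter). Compound 3 is estimated at 10000 nM, within a range of 4500 nM to 22000 nM.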

Compound 3, half-maximal inhibitory concentration: 18500 nM
Estimate against measurement, compound 3: 1.9-fold (0.27 log units) below; low and high end bracket the measured number.
By their numbers in this assay, from the lowest: compounds 2, 1 and 3 (each within the scatter of the next, the first and the last beyond it).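

Within this assay, the change from 3-hydroxyphenyl to 2,3-dichlorophenyl gives the first step beyond the scatter (a 2.7-fold higher number from compound 2 to compound 3 (0.43 log units; beyond the scatter)). Chloro in place of hydrogen on an aromatic carbon, by contrast, stays within the scatter (a 1.6-fold higher number from compound 1 to compound 3 (0.19 log units; within the scatter)), so that added chloro alone shows no clear change. Nothing available gives a reason for either step.

On these data alone, how an amine or a carboxylic acid on this ring would read remains open. So does whether the same steps would appear in any other cell type.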